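This account rests on a few compounds, and the source may have more. Where it says the series, first, only, none or still open, it means among the compounds named here.

In a functional assay on HL-60 cells (Homo sapiens) for cytotoxicity, with a stated time of 24 h (on this read-out higher numbers stand for lower toxicity in this test and lower numbers for higher toxicity in this test), compound 1 (`CN(C)c1ccc(/C=C2\CCC/C(=C\c3ccccc3[N+](=O)[O-])C2=O)cc1`) gives > 400000 nM as its reading, which is a limit of the assay and not a number. Within the data shown here, compound 2 (`O=C1/C(=C/c2ccc(F)cc2)CCC/C1=C\c1ccc([N+](=O)[O-])cc1`) gives 32000 nM as the only actual number so far. Its place can be judged only against that limit. Compound 3 (`CN(C)c1ccc(/C=C2\CCC/C(=C\c3ccc([N+](=O)[O-])cc3)C2=O)cc1`) differs from compound 2 by having dimethylamino in place of fluoro on an aromatic carbon, para to a large group (dimethylamino in place of fluoro on an aromatic carbon). Among the measured compounds shown here, no measured step shows this exchange. Compound 1 also carries dimethylamino, and its reading of > 400000 nM is again the limit. A rise beyond the scatter, toward lower toxicity, is therefore expected, with the estimated move a 2.8-fold higher number from compound 2 to compound 3 (0.45 log units; beyond the scatter) resting on that one limit. Compound 3 is estimated at 90000 nM (expected range 25000 nM to 350000 nM).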

Compound 3, half-maximal cytotoxic concentration: > 400000 nM
Compound 3 was reported as a limit; the forecaster's own chance of this, stated with the estimate: 20%; middle value at least 4.4-fold (0.64 log units) from the limit.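

In this assay, among these compounds, dimethylamino in place of fluoro on this aromatic carbon, para to a large group, gives an at least 12-fold higher number from compound 2 to compound 3 (1.09 log units; beyond the scatter), the only readable step at this position, and it runs toward lower toxicity in this test. From the compounds shown here alone, compound 3 reads > 400000 nM, which is a limit and not a number, so the full size of this change stays unknown. The step between compound 1 and compound 3 also cannot be read, since both readings sit at the same limit: the limit of > 400000 nM in this assay, at which 2 of the 3 values shown sit.

The compounds shown leave open whether a plain amino group or a methoxy group at this place would give a measurable reading between those of compound 2 and compound 3. They also leave open how the dimethylamino change would read with a carboxylic acid in place of the nitro group on the other aromatic ring.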